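Ethoxy on the aromatic ring of a melatonin receptor ligand

The source may hold more compounds than are shown below. What is called first, only, known or untested is meant among the compounds shown, and "the series" means these compounds.

Measured compounds:
compound 1 `COc1cccc(CCCNC(C)=O)c1` — 0.751 nM
compound 2 `CCCC(=O)NCCCc1cc(OC)ccc1OCc1ccccc1` — 0.00103 nM

Compound 1 `COc1cccc(CCCNC(C)=O)c1` was tested in an assay on CHO cells for displacement of a labelled ligand from melatonin receptor type 1B (Homo sapiens), read by scintillation counting, with a stated time of 60 min (on this read-out higher numbers stand for weaker inhibition and lower numbers for stronger inhibition), where compound 1 gives 0.751 nM. Among the measured compounds shown here, of the two numbers known here, compound 1 has the highest; the nearest is compound 2 `CCCC(=O)NCCCc1cc(OC)ccc1OCc1ccccc1`, for which compound 2 gives 0.00103 nM, a far lower number and a gap well beyond the scatter. For the measured compounds named here, compound 2 differs from compound 1 in more than one place, so its two values show only that a more substituted analogue binds much more strongly.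

Compound 3 `CCOc1ccc(OC)cc1CCCNC(C)=O` differs from compound 1 in a single place: ethoxy in place of hydrogen on an aromatic carbon. Going by the values given here, no step of this kind has been measured. The expectation for compound 3 is a lower number than compound 1, with a step of a 9.4-fold lower number from compound 1 to compound 3 (0.97 log units; beyond the scatter) that goes clearly beyond the scatter. Compound 3 is thus estimated at 0.08 nM, with a range from 0.01 nM to 0.5 nM.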

Compound 3, inhibition constant: 1.59 nM
The estimate for compound 3 lay 20-fold (1.30 log units) below the measured number; the measured number lies above the stated range.
By their numbers in this assay, from the lowest: compound 2; then compound 1; then compound 3.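

In this assay, among the compounds shown here, ethoxy in place of hydrogen on this aromatic carbon, ortho to a group of 7 heavy atoms and para to a methoxy group, gives a 2.1-fold higher number from compound 1 to compound 3 (0.33 log units; beyond the scatter) as the first change that can be read in one place. This position therefore accepts ethoxy, but here the group brings a small loss rather than a gain in binding, something the multiple differences between compound 1 and compound 2 could not show. Nothing available bears on why the number moves this way.

From the compounds shown here alone, it remains open whether a shorter or longer group at this carbon, such as a hydroxyl or a propoxy chain, would change the number in the same direction. Also open, going by these compounds, is how an amine at this carbon would compare with ethoxy.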